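The source may hold more compounds than are shown below. What is called first, only, known or untested is meant among the compounds shown, and "the series" means these compounds.

Working notes on the endoperoxide acid series.

Compound 1 `C=C1CCC[C@H]2[C@](C)(CC[C@]3(C)CC[C@@H]([C@@H](C)C(=O)O)OO3)[C@@H](C)CC[C@]12C` is the reference point. In a functional assay on EKVX cells (Homo sapiens) for inhibition (a higher number here means a weaker inhibitor of growth, a lower number a stronger inhibitor of growth), compound 1 gives 1090 nM, the lower of the two numbers in hand. Compound 3 `C=C1CCCC(C)(C)C1CC[C@@]1(C)CC[C@H]([C@@H](C)C(=O)O)OO1` keeps the same acid side chain and peroxide ring on a simpler carbocyclic portion; in this assay compound 3 gives 3190 nM, a higher number than compound 1 and beyond the usual scatter. Compound 2 `CC1=C(CC/C(C)=C/CC[C@@]2(C)CC[C@@H]([C@H](C)C(=O)O)OO2)C(C)(C)CCC1` carries an open, unsaturated chain in place of the fused ring system. In this assay compound 2 gives > 100000 nM, which is a limit of the assay and not a number; it sits at the limit of > 100000 nM in this assay, at which 1 of the 3 values shown sits.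

Compound 4 `C=C1CCC[C@H]2[C@](C)(CC[C@]3(C)CC[C@H]([C@@H](C)C(=O)O)OO3)[C@@H](C)CC[C@]12C` is the next point. Against compound 1 the change is the two compounds have the same atoms and bonds and differ only in configuration as drawn: 1 of 7 stereo elements differ; a stereocentre at a saturated ring carbon is drawn S in compound 1 and R in compound 4. Going by the values given here, no measured pair in this set isolates such an inversion, so the size of the step in this assay is not anchored by data. A moderate loss, beyond the scatter but well short of the limit, is taken as the expectation, a 2.3-fold higher number from compound 1 to compound 4 (0.36 log units; beyond the scatter). Compound 4 is therefore expected to give about 2500 nM in this assay, estimated within 600 nM to 10000 nM.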

Compound 4, concentration for 50% growth inhibition: 1170 nM
Estimate against measurement, compound 4: 2.1-fold (0.33 log units) above; measured number inside the range.
By their numbers in this assay, from the lowest: compounds 1 and 4 (each within the scatter of the next); then compound 3. At a limit, above all of these: compound 2.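

Going by these compounds alone, this is the first measured pair that isolates a single change, and in this assay drawing a stereocentre at a saturated ring carbon as R in place of S gives a 1.1-fold higher number from compound 1 to compound 4 (0.03 log units; within the scatter). Within the data shown here, on the core of compound 1, inversion at this one position therefore produces no step that can be told from the scatter, and neither compound ranks above the other. The pair is clean on the structural side, with nothing entering or leaving, so configuration at this carbon is the only variable being read: the fact that compounds 1 and 4 differ only in the configuration as drawn

Still open, from the compounds shown here alone, is whether the same inversion stays this small on the simpler carbocyclic portion of compound 3 or on the open, unsaturated chain of compound 2, and whether inverting any of the other stereo elements gives a step beyond the scatter. Also open is how this configuration behaves when the carboxylic acid of the side chain is replaced by a methyl ester or a primary amide, since every compound shown carries the acid.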